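This account rests on a few compounds, and the source may have more. Where it says the series, first, only, none or still open, it means among the compounds named here.

Among the compounds with values here, compound 2, with the structure `COc1ccc(/C=C/c2cc(OC)cc(OC)c2/C=C/C(=O)c2cc3ccc(Cl)cc3oc2=O)cc1`, holds the only number recorded in an assay on isolated protein for inhibition of Amine oxidase [flavin-containing] B (Homo sapiens), read by fluorescence, with a stated time of 15 min; on this read-out higher numbers stand for weaker inhibition and lower numbers for stronger inhibition: compound 2 gives 7360 nM. Compound 1, with the structure `COc1ccc(/C=C/c2cc(OC)cc(OC)c2/C=C/C(=O)c2cc3cc(OC)ccc3oc2=O)cc1`, is the other member of the set. For compound 1, this assay reports only the limit > 60000 nM, which is a limit of the assay and not a number; it corresponds to the limit of > 60000 nM in this assay, at which 1 of the 2 values shown sits. Compound 3, with the structure `COc1ccc(/C=C/c2cc(OC)cc(OC)c2/C=C/C(=O)c2cc3ccc(C)cc3oc2=O)cc1`, has not been measured in this assay. It differs from compound 2 in one place: methyl in place of chloro on an aromatic carbon. Within the data shown here, no step between measured compounds connects these two. The swap of one heavy atom for another of the same size, with no change in donors, acceptors or charge, is expected to move the value little, and the estimated step from compound 2 to compound 3 in this assay is a 1.4-fold higher number from compound 2 to compound 3 (0.13 log units; within the scatter), within or just beyond the usual scatter. Compound 3 is therefore estimated at 10000 nM, with a range from 3500 nM to 30000 nM.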

Compound 3, half-maximal inhibitory concentration: 2780 nM
Beside the measured number, compound 3's estimate is 3.6-fold (0.56 log units) above it; measured number outside the range, below it.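

In this assay, within the data shown here, methyl in place of chloro on this aromatic carbon, meta to a fused ring and para to a fused ring, gives a 2.6-fold lower number from compound 2 to compound 3 (0.42 log units; beyond the scatter), the only step that can be read in the set. It shows that this position responds to the change: swapping one heavy atom for another, with no change in donors, acceptors or charge, still moves the number beyond the scatter. No measurement shown accounts for this step.

Going by these compounds, whether an ethyl, an amine or a carboxylic acid on the same carbon would lower the number further or raise it stays open. On these data alone, with a single step, it is also open whether methyl in place of chloro would have the same effect on another carbon of this ring.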